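A few compounds are considered here, and "the series" means these few. Any claim that something is new, unique, unknown or untested is made for them only; others in the source may bear on it.

Of the compounds shown here, three that share one core have been measured in an ADME assay on the whole organism for inhibition, with Oryza sativa as the target, with a stated time of 4 days; a lower number here means a stronger inhibitor, a higher number a weaker inhibitor. Compound 1 `CCN(c1nc(Cl)nc(N[C@@H](C)c2ccccc2)n1)C(C)C` gives 537 nM, compound 2 `CCNc1nc(Cl)nc(N[C@H](C)c2ccccc2)n1` gives 14100 nM, and compound 3 `CCN(c1nc(Cl)nc(N[C@H](C)c2ccccc2)n1)C(C)C` gives 3550 nM. Compound 1 holds the lowest of the three numbers; compound 3 is its nearest neighbour and compound 2 lies furthest from it. The step of a 6.6-fold higher number from compound 1 to compound 3 (0.82 log units; beyond the scatter) rests on (the fact that compounds 1 and 3 differ only in the configuration as drawn). The step of a 4.0-fold lower number from compound 2 to compound 3 (0.60 log units; beyond the scatter) shows that isopropyl in place of hydrogen on a nitrogen on an aromatic ring lowers the number.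

The unmeasured compound 4 `CCCN(CCC)c1nc(Cl)nc(N[C@@H](C)c2ccccc2)n1` differs from compound 1 by dipropylamino in place of ethyl(isopropyl)amino on an aromatic carbon. Neither measured step matches this change directly: the stereocentre is kept as drawn in compound 1, and the amino nitrogen remains fully substituted, only carrying a different pair of alkyl chains. The step from compound 2 to compound 3 shows that this nitrogen is sensitive to what it carries, yet compound 1 and compound 4 both bear two chains there. Compound 4 is expected to stay close to compound 1, with a step of a 1.5-fold higher number from compound 1 to compound 4 (0.17 log units; within the scatter) that may not exceed the scatter. The estimate for compound 4 in this assay is 800 nM, within a range from 250 nM to 2500 nM.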

Compound 4, half-maximal inhibitory concentration: 331 nM
For compound 4 the middle estimate is 2.4-fold (0.38 log units) above the measured one; the measured number falls inside the stated range.
By their numbers in this assay, from the lowest: compounds 4 and 1 (each within the scatter of the next); then compound 3; then compound 2.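

Setting dipropylamino in place of ethyl(isopropyl)amino on the aromatic carbon opposite the ring nitrogen gives, in this assay, a 1.6-fold lower number from compound 1 to compound 4 (0.21 log units; within the scatter). Within the data shown here, the earlier compounds showed only that the number at this position differs between a nitrogen carrying a hydrogen and one carrying isopropyl; this pair shows that, with two chains kept on the nitrogen and the stereocentre drawn S, the isopropyl group is not needed for a number in this range, as compound 1 and compound 4 cannot be told apart here. Nothing measured here speaks to why these two amino groups read alike.

Dipropylamino is shown only with the stereocentre drawn S, so it stays open whether the gap seen in a 6.6-fold higher number from compound 1 to compound 3 (0.82 log units; beyond the scatter) would recur with this amino group. Also open, from the compounds shown here alone, is how the number would respond at the same position to a longer chain, as in dibutylamino, or to an amine carrying a methoxyethyl chain.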